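This account rests on a few compounds, and the source may have more. Where it says the series, first, only, none or still open, it means among the compounds named here.

Measured in a functional assay on U-937 cells (Homo sapiens) for cytotoxicity, read by MTT assay, with a stated time of 72 h; a lower number here means a stronger inhibitor, a higher number a weaker inhibitor:
- compound 1 `Cc1c(C)c2c(c(C)c1OC(=O)CCC(=O)NC1CC(C)(C)N([O])C(C)(C)C1)CC[C@@](C)(CCC[C@H](C)CCC[C@H](C)CCCC(C)C)O2` gives 76000 nM
- compound 2 `Cc1c(C)c2c(c(C)c1OC(=O)CCC(=O)O)CCC(C)(C(=O)NC1CC(C)(C)N([O])C(C)(C)C1)O2` gives 123000 nM

Compound 2 lies within the usual scatter of compound 1 , so these two values do not separate. Compound 3 `Cc1c(C)c2c(c(C)c1O)CCC(C)(C(=O)NC1CC(C)(C)N([O])C(C)(C)C1)O2` follows from compound 2 by one change: hydrogen in place of (2-carboxyethyl)carbonyl on an oxygen on an aromatic ring. Among the compounds with values here, no measured pair yet shows this change. The expected step in this assay is small, a 1.9-fold lower number from compound 2 to compound 3 (0.28 log units; within the scatter), estimated as no clear move beyond the scatter and, if anything, toward a lower number. For compound 3 the estimate is 65000 nM, with an expected range of 20000 nM to 170000 nM.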

Compound 3, half-maximal inhibitory concentration: 161000 nM
Estimate against measurement, compound 3: 2.5-fold (0.39 log units) below; the range from low to high includes it.
By their numbers in this assay, from the lowest: compounds 1, 2 and 3 (each within the scatter of the next, the first and the last beyond it).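

In this assay, hydrogen in place of (2-carboxyethyl)carbonyl on an oxygen on an aromatic ring gives a 1.3-fold higher number from compound 2 to compound 3 (0.12 log units; within the scatter). Within the data shown here, this is the first readable step at this position, and the free hydroxy and the ester carrying the carboxylic acid end do not separate here. No measured evidence bears on the reason for this result.

Still open, from the compounds shown here alone, is whether a different group on this oxygen, such as a simple acetyl, a longer acyl chain or an acyl chain ending in an amine, would give a step beyond the scatter.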